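Nitroimidazooxazine series: cytotoxicity on Vero cells

The compounds below may be only part of what the source reports. "The series", "measured", "known", "first", "only" and "open" are said of these compounds alone.

Compound 1 `O=[N+]([O-])c1cn2c(n1)OCC(COc1ccc(-c3ccc(C(F)(F)F)cc3)cc1)C2` and compound 2 `O=[N+]([O-])c1cn2c(n1)OCC(COc1ccc(-c3ccc(F)cc3)cc1)C2` share a core and differ only at the terminal aromatic ring: fluoro in place of trifluoromethyl on an aromatic carbon. In an ADME assay on Vero cells (Chlorocebus sabaeus) for cytotoxicity, with a stated time of 72 h (on this read-out higher numbers stand for weaker inhibition and lower numbers for stronger inhibition), compound 1 gives > 128000 nM, which is a limit of the assay and not a number. In this assay compound 2 likewise gives > 128000 nM, again a limit. The step that the two limits leave unreadable from compound 1 to compound 2 therefore cannot be read, because both values sit at the limit of > 128000 nM in this assay, at which 2 of the 3 values shown sit.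

Compound 3 `O=[N+]([O-])c1cn2c(n1)OCC(COCc1ccc(-c3ccc(C(F)(F)F)cc3)cc1)C2` carries the same trifluoromethyl-bearing biaryl but on a different core; the difference between the two cores is not broken down here. In this assay, among the measured compounds shown here, compound 3 gives 38000 nM, the only measured number in the set.

Compound 4 `O=[N+]([O-])c1cn2c(n1)OCC(COCc1ccc(-c3ccc(F)cc3)cc1)C2` is not yet measured; it relates to compound 3 as compound 2 relates to compound 1: fluoro in place of trifluoromethyl on an aromatic carbon. The place is the same in both pairs, so this is the same change. For the measured compounds named here, with the earlier step unreadable and no other pair to lean on, the expectation for compound 4 rests on the value of compound 3 and is weak: the step is estimated at a 1.8-fold higher number from compound 3 to compound 4 (0.27 log units; within the scatter). Compound 4 is expected at about 70000 nM, within 30000 nM to 128000 nM.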

Compound 4, half-maximal inhibitory concentration: 24000 nM
For compound 4 the middle estimate is 2.9-fold (0.46 log units) above the measured one; measured number below the stated range.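

In this assay, fluoro in place of trifluoromethyl on the core of compound 3 gives a 1.6-fold lower number from compound 3 to compound 4 (0.20 log units; within the scatter), so compound 3 and compound 4 cannot be told apart on this read-out. The same change on the core of compound 1 cannot be read, because compound 1 and compound 2 both stand at a limit of the assay and not at a number: the limit of > 128000 nM in this assay, at which 2 of the 4 values shown sit. Carrying the change from one core to the other is therefore neither supported nor contradicted, since one readable pair shows nothing beyond the scatter on one core and says nothing about the size of the step on the other.

The compounds shown leave open how a nitrile, an amine or a carboxylic acid in place of fluoro on the terminal ring would read on either core. They also leave open whether a longer chain joining the biaryl to the core would give a readable number on the core of compound 1.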